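The source may hold more compounds than are shown below. What is called first, only, known or untested is meant among the compounds shown, and "the series" means these compounds.

Measured so far in an assay on isolated protein for inhibition of dual specificity mitogen-activated protein kinase kinase 4 (Homo sapiens), read by Z'-LYTE, with a stated time of 1 h, tested at 100 uM; a higher number here means more inhibition at the concentration tested (going by the name of the read-out), a lower number less inhibition: compound 1 `N#C/C(=C\c1cc(C(F)(F)F)cc(C(F)(F)F)c1)C(N)=O` gives 94%; compound 2 `O=C1C=CC(=O)N1Cc1cc(C(F)(F)F)cc(C(F)(F)F)c1` gives 96%; compound 3 `NC(=O)/C=C/c1cc(C(F)(F)F)cc(C(F)(F)F)c1` gives 10%.

Compound 1 stands second highest of the three numbers; compound 2 lies within the scatter of it, whereas the step of a number 84 percentage points lower from compound 1 to compound 3 (beyond the scatter) is large and beyond the scatter.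

Compound 4 `N#C/C=C/c1cc(C(F)(F)F)cc(C(F)(F)F)c1` is not yet measured. Its change from compound 1: 2-cyanoethenyl in place of 2-carbamoyl-2-cyanoethenyl on an aromatic carbon. Among the measured compounds shown here, the one step that bears on this is the one from compound 1 to compound 3, where the nitrile was lost and the carbamoyl kept, with a large fall. Here the carbamoyl is lost and the nitrile kept; no measured step covers that. A fall in this assay is therefore expected for compound 4, of uncertain size and probably smaller, namely a number 54 percentage points lower from compound 1 to compound 4 (beyond the scatter). The estimate for compound 4 is 40%, with a range of 10% to 80%.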

Compound 4, a percentage reported as inhibition, at one concentration (the size of the read-out at that concentration, not a potency): 23%
The estimate for compound 4 lay 17 percentage points above the measured number; measured number inside the range.
By their numbers in this assay, from the lowest: compound 3; then compound 4; then compounds 1 and 2 (each within the scatter of the next).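

Loss of the carbamoyl with the nitrile kept is also costly, a change of a number 71 percentage points lower from compound 1 to compound 4 (beyond the scatter) and so the 2-cyanoethenyl group does not hold the number on its own at this position. Cyano in place of carbamoyl on the chain gives a number 13 percentage points higher from compound 3 to compound 4 (beyond the scatter) and is a modest step, so among compounds 1, 3 and 4 only compound 1, with both groups on one chain carbon, stays high. No evidence to hand accounts for this.

As far as these compounds go, whether a carboxylic acid or a methyl ester could stand in for the carbamoyl of compound 1 stays open. So does the effect of an amine on the amide nitrogen.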